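Chain length and inhibition in the hydroxamic acid series

The source may hold more compounds than are shown below. What is called first, only, known or untested is meant among the compounds shown, and "the series" means these compounds.

Values in a functional assay on A549 cells (Homo sapiens) for inhibition, read by MTT assay, with a stated time of 72 h; on this read-out higher numbers stand for weaker inhibition and lower numbers for stronger inhibition
- Compound 1 `Nc1ncnc2c1c(-c1cnc3[nH]ccc3c1)nn2CCCCCCCCC(=O)NO` gives 12300 nM
- Compound 2 `Nc1ncnc2c1c(-c1cnc3[nH]ccc3c1)nn2CCC(=O)NO` gives > 150000 nM
- Compound 3 `Nc1ncnc2c1c(-c1cnc3[nH]ccc3c1)nn2CCCC(=O)NO` is not yet measured

Compound 2 stands at the limit of > 150000 nM in this assay, at which 1 of the 2 values shown sits, and so has no exact number. Compound 3 differs from it by (hydroxycarbamoyl)methyl in place of hydroxycarbamoyl on a saturated chain carbon, two bonds along the chain from an aromatic nitrogen and thus has (hydroxycarbamoyl)methyl in place of hydroxycarbamoyl. Among the compounds with values here, the one measured step bearing on this is large: an at least 12-fold higher number from compound 1 to compound 2 (1.08 log units; beyond the scatter) in the same series. Compound 3 recovers only a small part of that chain, so a modest move toward lower numbers is expected in this assay and may not clear the limit. The expected change is an at least 1.6-fold lower number from compound 2 to compound 3 (0.22 log units; that floor lies within the scatter) on this estimate. Compound 3 is estimated at 90000 nM (range 30000 nM to 250000 nM)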

Compound 3, half-maximal inhibitory concentration: > 150000 nM
Compound 3: no number, only a limit; the forecaster's own chance of this, stated with the estimate: 40%; middle value at least 1.6-fold (0.22 log units) from the limit.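

In this assay compound 3 gives > 150000 nM, a limit of the assay and not a number. The added (hydroxycarbamoyl)methyl chain extension therefore gives no readable gain, and the step between compound 2 and compound 3 cannot be read: the limit of > 150000 nM in this assay, at which 2 of the 3 values shown sit. Within the data shown here, the long chain of compound 1 remains the only one with an exact value, and shortening it as far as compound 3 still gives an at least 12-fold higher number from compound 1 to compound 3 (1.08 log units; beyond the scatter).

Open, on these data alone, is the chain length between compound 3 and compound 1 at which exact values begin. Also open, as far as these compounds go, is whether a longer chain than that of compound 1, or a carboxylic acid in place of hydroxycarbamoyl, changes the read-out.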